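Imidazoline to imidazole on the oxazolyl-aniline core

The source may hold more compounds than are shown below. What is called first, only, known or untested is meant among the compounds shown, and "the series" means these compounds.

Measured so far:
compound 2 `c1ccc(-c2cnco2)c(NCC2=NCCN2)c1` — < 5020 nM
compound 1 `CS(=O)(=O)c1ccccc1NCc1c[nH]cn1` — < 100000 nM

In a functional assay for activation of Alpha-1D adrenergic receptor (Homo sapiens) (on this read-out lower numbers stand for an effect already at smaller amounts and higher numbers for an effect only at larger amounts of compound), compound 2 stands only at an assay limit, not a number (the limit of < 5020 nM in this assay, at which 1 of the 2 values shown sits). Compound 1 likewise gives only a limit (the limit of < 100000 nM in this assay, at which 1 of the 2 values shown sits). Compound 3 `c1ccc(-c2cnco2)c(NCc2c[nH]cn2)c1` differs from compound 2 by a group of 5 heavy atoms (3 carbon, 2 nitrogen; one five-membered aromatic ring with 2 hetero atoms) in place of a group of 5 heavy atoms (3 carbon, 2 nitrogen; one five-membered non-aromatic ring with 2 hetero atoms), on a saturated chain carbon bound to a nitrogen on an aromatic ring. Among the measured compounds shown here, no measured pair covers this change, so no step is known. In this assay the change is expected to shift the read-out towards weaker activation, beyond the usual scatter: an at least 2.9-fold higher number from compound 2 to compound 3 (0.47 log units; beyond the scatter). Compound 3 is therefore estimated at 15000 nM, with a range from 1500 nM to 100000 nM, and a fair chance that only a limit is reported.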

Compound 3, half-maximal effective concentration: < 252 nM
Compound 3 gave a limit, no number; the forecaster's own chance of this, stated with the estimate: 50%; at least 59-fold (1.77 log units) between middle value and limit.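

In this assay compound 3 gives only the limit < 252 nM and no number. Among the compounds shown here, compound 1 and compound 2 also stand at limits, so no step to compound 3 can be read. On these data alone, how strongly any of the three compounds activates the receptor remains open.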